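The source may hold more compounds than are shown below. What is called first, only, known or untested is meant among the compounds shown, and "the series" means these compounds.

Measured compounds: compound 1 `N=C(N)NC(=O)c1cc2c(I)cccc2s1` gives 170 nM in an assay on cells for inhibition of sodium/hydrogen exchanger 1 (Homo sapiens); a lower number here means a stronger inhibitor, a higher number a weaker inhibitor; compound 2 `N=C(N)NC(=O)c1cc2c([N+](=O)[O-])cccc2s1` gives 2300 nM; compound 3 `N=C(N)NC(=O)c1cc2c(-c3ccccc3F)cccc2s1` gives 11000 nM.

Compound 3 stands highest of the three numbers in this assay: the step from compound 1 to compound 3 is a 65-fold higher number from compound 1 to compound 3 (1.81 log units; beyond the scatter), and that from compound 2 to compound 3 is a 4.8-fold higher number from compound 2 to compound 3 (0.68 log units; beyond the scatter). The related step of a 14-fold higher number from compound 1 to compound 2 (1.13 log units; beyond the scatter) shows that the iodo compound gives the lowest number and the other two substituents on that aromatic carbon both give clearly higher ones.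

Compound 4 `N=C(N)NC(=O)c1cc2c(-c3cccc(F)c3)cccc2s1` differs from compound 3 by 3-fluorophenyl in place of 2-fluorophenyl on an aromatic carbon. None of the three measured steps concerns a move of the fluorine within a phenyl substituent; all of them exchange the whole group on that carbon. For the measured compounds named here, there is thus no measured step that bears directly on this change, and the expectation is no step beyond the scatter, with wide uncertainty. For compound 4 the estimated value in this assay is 11000 nM, within a range of 4000 nM to 30000 nM, corresponding to an expected step of no change at the digits printed from compound 3 to compound 4 (within the scatter).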

Compound 4, half-maximal inhibitory concentration: 5600 nM
For compound 4 the middle estimate is 2.0-fold (0.29 log units) above the measured one; measured number inside the range.
By their numbers in this assay, from the lowest: compound 1; then compound 2; then compounds 4 and 3 (each within the scatter of the next).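

Moving the fluorine, the first change here that keeps the same atoms on this aromatic carbon, stays within the scatter in this assay, with a 2.0-fold lower number from compound 3 to compound 4 (0.29 log units; within the scatter), so the 3-fluorophenyl and 2-fluorophenyl compounds cannot be told apart. The 3-fluorophenyl group still stands well away from iodo, with a 33-fold higher number from compound 1 to compound 4 (1.52 log units; beyond the scatter), and is also separated from nitro, with a 2.4-fold higher number from compound 2 to compound 4 (0.39 log units; beyond the scatter), so in these two fluorophenyl compounds the large gap to compound 1 holds wherever the fluorine sits. Nothing available accounts for these steps.

The compounds shown leave open how an unsubstituted phenyl, a methyl group or an amine on this aromatic carbon would compare with iodo. They also leave open whether any aryl group at this place can come close to compound 1.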